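The source may hold more compounds than are shown below. What is called first, only, known or untested is meant among the compounds shown, and "the series" means these compounds.

Of the compounds shown here, three have so far been measured in an assay on HEK293 cells for agonist activity at transient receptor potential cation channel subfamily M member 8 (Homo sapiens), read by fluorescence and calcium flux, with a stated time of 15 min; on this read-out lower numbers stand for an effect already at smaller amounts and higher numbers for an effect only at larger amounts of compound. Compound 1 `Cc1ccc(OCC(=O)N(Cc2cccs2)c2cnn(C)c2)cc1` gives 63000 nM, the highest of the three numbers. Compound 2 `CCN(Cc1ccoc1)C(=O)COc1ccc(C)cc1` gives 136 nM, and compound 3 `CCN(Cc1ccsc1)C(=O)COc1ccc(C)cc1` gives 88 nM; the gaps from compound 1 to each of these lie well beyond the scatter. Among the measured compounds shown here, compounds 2 and 3 differ from each other in one place, and that step, a 1.5-fold lower number from compound 2 to compound 3 (0.19 log units; within the scatter), is the only single-point comparison among the measured compounds.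

Compound 4 `Cc1ccc(OCC(=O)N(Cc2cccs2)c2ccncc2)cc1` has not yet been measured. It differs from compound 1 in one place: pyridin-4-yl in place of 1-methyl-1H-pyrazol-4-yl on an amide-type nitrogen. For the measured compounds named here, the one measured step concerns another position, the saturated chain carbon bound to the amide-type nitrogen, and it stayed within the scatter; no measured pair shows an exchange of the group on the amide-type nitrogen itself. Compounds 2 and 3 carry a different group at that nitrogen and sit far from compound 1, but that is not the exchange made here, so nothing measured speaks directly for or against a shift. A step of a 1.4-fold lower number from compound 1 to compound 4 (0.15 log units; within the scatter) is therefore expected, small against the scatter. In this assay compound 4 is estimated at 45000 nM, with a range from 10000 nM to 150000 nM.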

Compound 4, half-maximal effective concentration: 52 nM
For compound 4 the middle estimate is 870-fold (2.94 log units) above the measured one; measured number outside the range, below it.
By their numbers in this assay, from the lowest: compounds 4, 3 and 2 (each within the scatter of the next, the first and the last beyond it); then compound 1.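

In this assay, the group on the amide-type nitrogen proves to be a highly sensitive position: pyridin-4-yl in place of 1-methyl-1H-pyrazol-4-yl gives a 1200-fold lower number from compound 1 to compound 4 (3.08 log units; beyond the scatter) and so moves the shared core from the far end of the measured series to the low end. The only earlier single-point step, a 1.5-fold lower number from compound 2 to compound 3 (0.19 log units; within the scatter) on exchanging furan-3-yl for thiophen-3-yl on the saturated chain carbon, had shown no change beyond the scatter and gave no sign of such sensitivity at the amide-type nitrogen. The two exchanged groups match in heavy atom count, have no hydrogen-bond donors and carry no net charge, differing in ring size, hetero atoms and hydrogen-bond acceptors, but no available evidence accounts for the step or shows which of these differences matters.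

The compounds shown leave open whether pyridin-3-yl or a plain phenyl ring on the amide-type nitrogen would keep the low number of compound 4 or return towards the high number of compound 1. They also leave open whether the effect of this exchange depends on the thiophen-2-yl group that compounds 1 and 4 share.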